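Working notes: aryl change on the ring amine

The source may report more compounds than this note shows. Statements on the series, on what has been measured and on what is new or still open speak of the compounds shown alone.

Measured so far:
compound 1, `CCCc1nc(-c2ccccc2)c(CNCCN2CCN(c3ccccc3Cl)CC2)o1`: 60.1%
compound 2, `CCCc1nc(-c2ccccc2)c(CNCCCN2CCN(c3ccc(C(F)(F)F)cc3)CC2)o1`: 51.6%

Two compounds carry a reading in an assay on HEK293 cells for inhibition of Voltage-dependent T-type calcium channel subunit alpha-1G (Homo sapiens), read by fluorescence, tested at 10 uM; on this read-out lower numbers stand for less inhibition and higher numbers for more inhibition at the one concentration tested (going by the name of the read-out). Compound 1 gives 60.1% and stands on the higher of the two numbers, but the gap to compound 2, which gives 51.6%, lies within the scatter, so the two are read as equivalent. For the measured compounds named here, compound 1 and compound 2 differ in more than one place, so no single-place step between measured compounds is available.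

Compound 3, `CCCc1nc(-c2ccccc2)c(CNCCN2CCN(c3cccc(C(F)(F)F)c3)CC2)o1`, is not yet measured. It differs from compound 1 in one place: 3-(trifluoromethyl)phenyl in place of 2-chlorophenyl on an amine nitrogen in a ring. Going by the values given here, with only two equivalent readings and no comparable step, no direction can be inferred; the step from compound 1 to compound 3 in this assay is expected to be a number 5.1 percentage points lower from compound 1 to compound 3 (within the scatter), none beyond the scatter. Compound 3 is expected to give about 55% in this assay, with a range from 35% to 75%.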

Compound 3, a percentage reported as inhibition, at one concentration (the size of the read-out at that concentration, not a potency): 56.3%
For compound 3 the middle estimate is 1.3 percentage points below the measured one; the measured number falls inside the stated range.
By their numbers in this assay, from the lowest: compounds 2, 3 and 1 (each within the scatter of the next).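

In this assay, the series now has its first single-place step: 3-(trifluoromethyl)phenyl in place of 2-chlorophenyl on an amine nitrogen in a ring gives a number 3.8 percentage points lower from compound 1 to compound 3 (within the scatter). At this position, an aryl group of 10 heavy atoms in place of one of 7 therefore leaves the reading within the scatter, so this exchange does not separate the two compounds on this read-out. No available measurement bears on the cause of this outcome.

From the compounds shown here alone, it remains open whether a pyridine ring or an unsubstituted phenyl at this position would move the reading beyond the scatter. Going by these compounds, the effect of a longer chain between the amine nitrogens, taken as a single change on the core of compound 3, also remains open.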